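Shortening the ether chain in a three-compound series

The source may hold more compounds than are shown below. What is called first, only, known or untested is meant among the compounds shown, and "the series" means these compounds.

Compound 1 `CCOc1cccc2cc(-c3ccc(Br)cc3)c(=O)oc12`: in an assay on CHO cells for displacement of a labelled ligand from adenosine receptor A2b (Homo sapiens), read by radioligand binding (on this read-out higher numbers stand for weaker inhibition and lower numbers for stronger inhibition), compound 1 gives > 30000 nM, a limit of the assay.
Compound 2 `CCOc1cccc2cc(-c3ccc(OC)cc3)c(=O)oc12`: in this assay compound 2 gives > 30000 nM, a limit of the assay.
Compound 3 `CCOc1cccc2cc(-c3ccc(OC)cc3OC)c(=O)oc12`: in this assay compound 3 gives > 30000 nM, a limit of the assay.

Compound 2 stands only at a limit, and the two further values shown are limits as well, so no order among the three is readable. The steps a step that the two limits leave unreadable from compound 1 to compound 2 and a step that the two limits leave unreadable from compound 2 to compound 3 are unreadable because all three values sit at the limit of > 30000 nM in this assay, at which 3 of the 3 values shown sit.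

Compound 4 `COc1ccc(-c2cc3cccc(OC)c3oc2=O)cc1` differs from compound 2 by hydrogen in place of methyl on a saturated chain carbon bound to an oxygen on an aromatic ring. Going by the values given here, no measured step bears on this change. Compound 4 is therefore expected to remain at the limit, estimated at 30000 nM with a range of 10000 nM to 100000 nM. The expected step of a number no higher from compound 2 to compound 4 (the limit leaves the size open) is estimated as none beyond the scatter.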

Compound 4, inhibition constant: > 30000 nM
Compound 4 was reported as a limit (the forecaster's own chance of this, stated with the estimate: 80%); the middle value lies on the limit itself.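

No new step can be read between compound 2 and compound 4, the ethoxy to methoxy change, because both values are limits: the limit of > 30000 nM in this assay, at which 4 of the 4 values shown sit. In this assay the compounds shown leave open whether any change on the shared core gives a value that is not a limit.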